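Dipentylamide variant of a stilbene cinnamamide series

The compounds below may be only part of what the source reports. "The series", "measured", "known", "first", "only" and "open" are said of these compounds alone.

Measured compounds:
Compound 1, `CCCCCCCCNC(=O)/C=C/c1c(/C=C/c2ccc(OC)cc2)cc(OC)cc1OC`, gives 4280 nM in a functional assay on MCF7 cells (Homo sapiens) for inhibition, read by MTT assay, with a stated time of 48 h; on this read-out lower numbers stand for stronger inhibition and higher numbers for weaker inhibition.
Compound 2, `C#CCNC(=O)/C=C/c1c(/C=C/c2ccc(OC)cc2)cc(OC)cc1OC`, gives 4560 nM in this assay.
Compound 3, `COc1ccc(/C=C/c2cc(OC)cc(OC)c2/C=C/C(=O)NC(C)C)cc1`, gives 2560 nM in this assay.

Compound 3 shows the lowest of the three numbers, but its gaps to the others are both within the scatter: a 1.7-fold lower number from compound 1 to compound 3 (0.22 log units; within the scatter) and a 1.8-fold lower number from compound 2 to compound 3 (0.25 log units; within the scatter). Compound 4, `CCCCCN(CCCCC)C(=O)/C=C/c1c(/C=C/c2ccc(OC)cc2)cc(OC)cc1OC`, arises from compound 3 by the change (dipentylamino in place of isopropylamino on a carbonyl carbon). The three measured steps all alter only the group on the amide-type nitrogen, and each stays within the scatter, including a 1.1-fold higher number from compound 1 to compound 2 (0.03 log units; within the scatter). None of them, however, removes the hydrogen-bond donor as this step does, so the bearing of those steps is limited. A modest shift, a 1.8-fold higher number from compound 3 to compound 4 (0.24 log units; within the scatter), is expected rather than a large one. Compound 4 is estimated to give 4500 nM in this assay, with a range from 1800 nM to 11000 nM.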

Compound 4, half-maximal inhibitory concentration: 6130 nM
Estimate against measurement, compound 4: 1.4-fold (0.13 log units) below; the measured number falls inside the stated range.
By their numbers in this assay, from the lowest: compounds 3, 1, 2 and 4 (each within the scatter of the next, the first and the last beyond it).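

Dipentylamino, which carries no amide hydrogen, gives the first step at this carbonyl carbon that lies beyond the scatter in this assay (a 2.4-fold higher number from compound 3 to compound 4 (0.38 log units; beyond the scatter)). Compound 4 does not separate from the propargylamino and octylamino amides (a 1.3-fold higher number from compound 2 to compound 4 (0.13 log units; within the scatter); a 1.4-fold higher number from compound 1 to compound 4 (0.16 log units; within the scatter)), so the gap holds against compound 3 alone. No measurement shown here accounts for this gap. The compounds leave open whether the missing amide hydrogen or the added chain length matters more. A dimethylamino or pentylamino group at this carbonyl carbon would bear on that question.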